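Isothiocyanate-bearing analogues on a shared core: linker exchange

The compounds below may be only part of what the source reports. "The series", "measured", "known", "first", "only" and "open" are said of these compounds alone.

Measured in a functional assay on A549 cells (Homo sapiens) for inhibition, read by CCK-8 assay, with a stated time of 72 h, tested at 1 uM; on this read-out higher numbers stand for a stronger effect at the one concentration tested and lower numbers for a weaker effect:
compound 1 `CN(C)C(=O)c1cc2cnc(Nc3ccc(S(=O)(=O)NCCCCN=C=S)cc3)nc2n1C1CCCC1`: 39.4%
compound 2 `CN(C)C(=O)c1cc2cnc(Nc3ccc(C(=O)NCCCCCCCN=C=S)cc3F)nc2n1C1CCCC1`: 0.05%
compound 3 `CN(C)C(=O)c1cc2cnc(Nc3ccc(C(=O)NCCCCN=C=S)cc3O)nc2n1C1CCCC1`: 30.3%

Compound 1 gives the highest of the three numbers in this assay. Its nearest neighbour is compound 3, whose number sits within the usual scatter, so the two cannot be ordered. Compound 2 lies far lower, a gap beyond the scatter. No pair among these three differs in only one place, so no single step can be read from them.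

Compound 4 `CN(C)C(=O)c1cc2cnc(Nc3ccc(NC(=O)CCCCCCN=C=S)cc3)nc2n1C1CCCC1` is not yet measured. It differs from compound 1 as follows: a group of 12 heavy atoms (8 carbon, 2 nitrogen, 1 oxygen, 1 sulfur; no ring) in place of a group of 11 heavy atoms (5 carbon, 2 nitrogen, 2 oxygen, 2 sulfur; no ring), on an aromatic carbon. The position is on an aromatic carbon of a six-membered aromatic ring of carbon only, para to a large group.

Going by the values given here, with no measured step that matches this exchange, the expectation for the step from compound 1 to compound 4 rests on the spread of the three numbers alone. A downward step of about the size of the scatter is expected, a number 11.4 percentage points lower from compound 1 to compound 4 (beyond the scatter). Compound 4 is accordingly estimated at 28% in this assay, within a range from 5% to 50%.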

Compound 4, a percentage reported as inhibition, at one concentration (the size of the read-out at that concentration, not a potency): 43.3%
The estimate for compound 4 lay 15.3 percentage points below the measured number; measured number inside the range.
By their numbers in this assay, from the lowest: compound 2; then compounds 3, 1 and 4 (each within the scatter of the next, the first and the last beyond it).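

Working notes: in this assay, the exchange at this position, on an aromatic carbon para to a large group, gives the first step that can be read in the series: a number 3.9 percentage points higher from compound 1 to compound 4 (within the scatter). The group of 12 heavy atoms, with 3 double bonds outside aromatic rings and 3 hydrogen-bond acceptors, can therefore take the place of the group of 11 heavy atoms, with 4 of each, without a change that this single-concentration read-out can separate from the scatter. No measurement shown bears on why the two compounds read alike.

Still open, as far as these compounds go, is whether the terminal isothiocyanate matters, which an amine or a carboxylic acid at the chain end of compound 4 would test. The exchange also alters the linking unit and the chain together, so a longer chain on the linking unit of compound 1 would be needed to separate the two.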